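This account rests on a few compounds, and the source may have more. Where it says the series, first, only, none or still open, it means among the compounds named here.

Series notes. Compound 1 `O=C([C@H]1CCN1S(=O)(=O)c1c(F)c(F)c(F)c(F)c1F)N(Cc1ccc(C2CCCCC2)cc1)c1ccc2c(=O)[nH]ccc2c1` gives 1400 nM in a functional assay on MDA-MB-231 cells (Homo sapiens) for antiproliferative activity, with a stated time of 72 h; on this read-out lower numbers stand for an effect already at smaller amounts and higher numbers for an effect only at larger amounts of compound. Compound 2 `O=C([C@H]1CCN1S(=O)(=O)c1c(F)c(F)c(F)c(F)c1F)N(Cc1ccc(C2CCCCC2)cn1)c1ccc2c(=O)[nH]ccc2c1` carries the change 5-cyclohexylpyridin-2-yl in place of 4-cyclohexylphenyl on a saturated chain carbon bound to an amide-type nitrogen and gives 1200 nM in this assay; the step is a 1.2-fold lower number from compound 1 to compound 2 (0.07 log units; within the scatter). Compound 3 `O=C([C@H]1CCN1S(=O)(=O)c1c(F)c(F)c(F)c(F)c1F)N(Cc1ccc(C2CCCCC2)cc1)c1cc2[nH]ncc2cc1F` differs from compound 1 in the core, the difference being (a group of 10 heavy atoms (7 carbon, 2 nitrogen, 1 fluorine; one five-membered aromatic ring with 2 hetero atoms, one six-membered aromatic ring of carbon only) in place of a group of 11 heavy atoms (9 carbon, 1 nitrogen, 1 oxygen; one six-membered aromatic ring of carbon only, one six-membered aromatic ring with 1 hetero atom), on an amide-type nitrogen). In this assay compound 3 gives 2400 nM, and the step is a 1.7-fold higher number from compound 1 to compound 3 (0.23 log units; within the scatter). Compound 4 `O=C([C@H]1CCN1S(=O)(=O)c1c(F)c(F)c(F)c(F)c1F)N(Cc1ccc(C2CCCCC2)cn1)c1cc2[nH]ncc2cc1F` is not yet measured. It differs from compound 3 by 5-cyclohexylpyridin-2-yl in place of 4-cyclohexylphenyl on a saturated chain carbon bound to an amide-type nitrogen, the same change as that from compound 1 to compound 2, at the same place. The expectation for compound 4 rests on that earlier pair: its step in this assay is estimated as a 1.2-fold lower number from compound 3 to compound 4 (0.08 log units; within the scatter), set beside the measured 1.2-fold lower number from compound 1 to compound 2 (0.07 log units; within the scatter). Compound 4 is therefore expected at 2000 nM, with an estimated range from 1000 nM to 4000 nM.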

Compound 4, half-maximal effective concentration: 2300 nM
Estimate against measurement, compound 4: 1.2-fold (0.06 log units) below, within the range that was stated.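

In this assay, placing 5-cyclohexylpyridin-2-yl in place of 4-cyclohexylphenyl gives a 1.0-fold lower number from compound 3 to compound 4 (0.02 log units; within the scatter), and this change reads alike on the two cores: the same change on two cores in this assay, a 1.2-fold lower number (0.07 log units; within the scatter) from compound 1 to compound 2 and a 1.0-fold lower number (0.02 log units; within the scatter) from compound 3 to compound 4, 1.1-fold (0.05 log units) apart, within the scatter of two such steps. The core change, read with 5-cyclohexylpyridin-2-yl in place, gives a 1.9-fold higher number from compound 2 to compound 4 (0.28 log units; within the scatter), and it also reads alike in both settings: the same change on two cores in this assay, a 1.7-fold higher number (0.23 log units; within the scatter) from compound 1 to compound 3 and a 1.9-fold higher number (0.28 log units; within the scatter) from compound 2 to compound 4, 1.1-fold (0.05 log units) apart, within the scatter of two such steps. Going by these compounds alone, all of these steps lie within the scatter, so the agreement shows only that neither change gave a step beyond the scatter in these four compounds, not that a real effect carries from one core to another.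

Open, as far as these compounds go, is whether a step beyond the scatter would carry over between these cores. Also open, from the compounds shown here alone, is how an amine or a carboxylic acid in place of the cyclohexyl group would read.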